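A few compounds are considered here, and "the series" means these few. Any claim that something is new, unique, unknown or untested is made for them only; others in the source may bear on it.

Measured in an ADME assay on cells (Fibroblast, Gallus gallus) for cytotoxicity, read by CCK-8 assay, with a stated time of 48 h; a higher number here means that more compound is tolerated, a lower number that less compound is tolerated:
- compound 1 `CCC(CC)O[C@@H]1C=C(C(=O)O)C[C@H](NCc2ccc(Oc3ccccc3)cc2)[C@H]1NC(C)=O`: > 200000 nM (a limit)
- compound 2 `CCC(CC)O[C@@H]1C=C(C(=O)O)C[C@H](NCc2ccc(SCC(C)C)cc2)[C@H]1NC(C)=O`: > 200000 nM (a limit)
- compound 3 `CCC(CC)O[C@@H]1C=C(C(=O)O)C[C@H](NCc2ccc(SC(C)CC)cc2)[C@H]1NC(C)=O`: > 200000 nM (a limit)

Compound 3 has no number, only a limit. It stands at the limit of > 200000 nM in this assay, at which 3 of the 3 values shown sit, so the series offers no measured value to anchor a comparison.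

The next step leads to compound 4 `CCC(CC)O[C@@H]1C=C(C(=O)O)C[C@H](NCc2ccc(Sc3cccs3)cc2)[C@H]1NC(C)=O`, with thiophen-2-yl in place of sec-butyl on a sulfur. Two measured changes bear on it most closely. One is a step that the two limits leave unreadable from compound 2 to compound 3, which alters the alkyl group on the same sulfur. The other is a step that the two limits leave unreadable from compound 1 to compound 3, which relates compound 3 to the phenoxy compound, and a step that the two limits leave unreadable from compound 1 to compound 2 gives the same picture. None of these steps has a size that can be read, so they set no direction for the change.

Compound 1 also carries an aromatic ring in this part of the molecule, and it too gives only a limit (> 200000 nM). In this assay, the expected result is therefore a number no higher from compound 3 to compound 4 (the limit leaves the size open), with no change expected beyond the scatter. Another reported limit is the likeliest outcome for compound 4. Compound 4 is estimated at 200000 nM, with an expected range from 100000 nM to 400000 nM.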

Compound 4, half-maximal cytotoxic concentration: > 200000 nM
Compound 4: only a limit was reported; the forecaster's own chance of this, stated with the estimate: 80%; the middle value lies on the limit itself.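

In this assay compound 4 gives > 200000 nM as a limit and not a number, so the steps to compound 4 from compound 1, compound 2 and compound 3 cannot be read. The compounds shown leave open what actual tolerated concentration any of the four has, and whether the group on the sulfur makes any difference to it.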